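Swapping the aryl group on the amide nitrogen

The source may hold more compounds than are shown below. What is called first, only, known or untested is meant among the compounds shown, and "the series" means these compounds.

Compound 1 `O=C(CN1CCN(c2nnc(Cc3ccncc3)c3ccccc23)CC1)Nc1ccc(F)c(Cl)c1`: 880 nM
Compound 2 `O=C(CN1CCN(c2nnc(Cc3ccncc3)c3ccccc23)CC1)Nc1c(F)cccc1F`: 28700 nM

In a functional assay on HT-29 cells (Homo sapiens) for cytotoxicity, read by MTT assay, with a stated time of 72 h (on this read-out lower numbers stand for stronger inhibition and higher numbers for weaker inhibition), compound 2 has the higher of the two numbers, 28700 nM, and so is the weaker of the pair. Compound 3 `Cc1ccccc1NC(=O)CN1CCN(c2nnc(Cc3ccncc3)c3ccccc23)CC1` keeps the shared core and changes one group: 2-methylphenyl in place of 2,6-difluorophenyl on an amide-type nitrogen. Here, 2-methylphenyl comes in place of 2,6-difluorophenyl on an amide-type nitrogen. Among the measured compounds shown here, one measured step bears on this change: a 33-fold higher number from compound 1 to compound 2 (1.51 log units; beyond the scatter). It involved the same amide-type nitrogen, so a swap there can move the number a long way in this assay. For the measured compounds named here, no measured compound carries 2-methylphenyl, so that single step gives only a rough guide. A moderate move toward a lower number is expected, with the estimated change being a 3.6-fold lower number from compound 2 to compound 3 (0.55 log units; beyond the scatter). Compound 3 is estimated at 8000 nM, with an expected range of 2000 nM to 30000 nM.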

Compound 3, half-maximal inhibitory concentration: 15000 nM
For compound 3 the middle estimate is 1.9-fold (0.27 log units) below the measured one; measured number inside the range.
By their numbers in this assay, from the lowest: compound 1; then compounds 3 and 2 (each within the scatter of the next).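

In this assay the swap from 2,6-difluorophenyl to 2-methylphenyl on the amide-type nitrogen gives a 1.9-fold lower number from compound 2 to compound 3 (0.28 log units; within the scatter) and so does not separate these two groups, even though one carries two fluorines and the other a methyl. Measured against the 3-chloro-4-fluorophenyl group, the new group gives a 17-fold higher number from compound 1 to compound 3 (1.23 log units; beyond the scatter) and so stands far from compound 1, just as the difluoro group does, which means that two different replacements now share the same large gap and compound 1 keeps the lowest number of the three. Nothing measured here explains this difference between the groups.

Still open, from the compounds shown here alone, is what a plain phenyl ring would give on this nitrogen. The same holds for a phenyl ring carrying only the chlorine or only the fluorine of compound 1, so the share of each atom in the lower number of compound 1 cannot yet be told.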